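Five-membered ring variation at the chain carbon

The source may report more compounds than this note shows. Statements on the series, on what has been measured and on what is new or still open speak of the compounds shown alone.

Compound 1 `N#Cc1ccc(OCc2ccsc2)cc1OC(C(=O)O)c1ccccc1Cl` — 17 nM
Compound 2 `N#Cc1ccc(OCc2ccsc2)cc1OC(C(=O)O)c1ccccc1Br` — 51 nM
Compound 3 `N#Cc1ccc(OCc2ccsc2)cc1OC(C(=O)O)c1ccoc1` — 2850 nM

All three were measured in an assay on A10 cells for antagonist activity at Endothelin-1 receptor (Rattus norvegicus); a higher number here means a weaker inhibitor, a lower number a stronger inhibitor. Compound 3 gives the highest number of the three: a 56-fold higher number from compound 2 to compound 3 (1.75 log units; beyond the scatter) and a 170-fold higher number from compound 1 to compound 3 (2.22 log units; beyond the scatter). Compound 4 `N#Cc1ccc(OCc2ccsc2)cc1OC(C(=O)O)c1ccsc1` differs from compound 3 by thiophen-3-yl in place of furan-3-yl on a saturated chain carbon bound to a carbonyl carbon and an oxygen on an aromatic ring. Within the data shown here, no measured step swaps one five-membered ring for another; the two large steps both replace 2-chlorophenyl or 2-bromophenyl by furan-3-yl, and the remaining step, a 3.0-fold higher number from compound 1 to compound 2 (0.48 log units; beyond the scatter), is a halogen swap. These show that the group on this chain carbon matters strongly but not how thiophen-3-yl compares with furan-3-yl. A small to modest step downward is expected, a 2.4-fold lower number from compound 3 to compound 4 (0.38 log units; beyond the scatter), with wide uncertainty. Compound 4 is estimated at 1200 nM in this assay, range 300 nM to 4000 nM.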

Compound 4, half-maximal inhibitory concentration: 630 nM
Compound 4: middle estimate off by 1.9-fold (0.28 log units), on the high side; low and high end bracket the measured number.
By their numbers in this assay, from the lowest: compound 1; then compound 2; then compound 4; then compound 3.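

Within the five-membered rings on this chain carbon, exchanging the ring oxygen for sulfur at an unchanged heavy-atom count still moves the result in this assay (a 4.5-fold lower number from compound 3 to compound 4 (0.66 log units; beyond the scatter)). Thiophen-3-yl closes only part of the gap to the halogen-bearing rings, and both remaining steps stay large (a 12-fold higher number from compound 2 to compound 4 (1.09 log units; beyond the scatter); a 37-fold higher number from compound 1 to compound 4 (1.57 log units; beyond the scatter)). The choice of five-membered ring therefore matters, but less than the change from 2-chlorophenyl or 2-bromophenyl to either five-membered ring.

As far as these compounds go, how an unsubstituted phenyl or a pyridine ring on this chain carbon would compare remains open, and such groups would help separate ring size from the halogen. No measured evidence bears on the reason for these differences.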